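Swapping cyclohexyl for 4-fluorophenyl on a carbonyl carbon

The source may report more compounds than this note shows. Statements on the series, on what has been measured and on what is new or still open speak of the compounds shown alone.

Among the compounds with values here, in an ADME assay on Vero cells (Chlorocebus sabaeus) for cytotoxicity, read by MTT assay, with a stated time of 72 h (a higher number here means that more compound is tolerated, a lower number that less compound is tolerated), compound 3 `O=C(C1CCCCC1)N1CCN(c2nc(=O)c3cc(C(F)(F)F)cc([N+](=O)[O-])c3s2)CC1` gives 88700 nM, the only actual number in this small set. Compound 1 `O=C(C1CC1)N1CCN(c2nc(=O)c3cc(C(F)(F)F)cc([N+](=O)[O-])c3s2)CC1` reads > 125000 nM, which is a limit and not a number. Compound 2 `CCCCC(=O)N1CCN(c2nc(=O)c3cc(C(F)(F)F)cc([N+](=O)[O-])c3s2)CC1` reads > 125000 nM, also a limit. Compound 4 `O=C(c1ccc(F)cc1)N1CCN(c2nc(=O)c3cc(C(F)(F)F)cc([N+](=O)[O-])c3s2)CC1` carries 4-fluorophenyl in place of cyclohexyl on a carbonyl carbon. Two measured steps changed the group at this same place: an at least 1.4-fold lower number from compound 1 to compound 3 (0.14 log units; that floor lies within the scatter) and an at least 1.4-fold lower number from compound 2 to compound 3 (0.14 log units; that floor lies within the scatter). Each gives only a floor, so neither shows a true size, and neither introduced an aromatic ring. The expected result is a 1.1-fold higher number from compound 3 to compound 4 (0.05 log units; within the scatter), with no clear move in either direction. For compound 4 the estimate is 100000 nM, with an expected range from 50000 nM to 200000 nM.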

Compound 4, half-maximal cytotoxic concentration: > 125000 nM
Compound 4 was reported as a limit; the forecaster's own chance of this, stated with the estimate: 35%; middle value at least 1.2-fold (0.09 log units) away from the limit.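

Compound 4 gives > 125000 nM in this assay, which is a limit and not a number. Within the data shown here, it is the first compound here with an aromatic ring at this carbonyl carbon, and the change from cyclohexyl to 4-fluorophenyl gives an at least 1.4-fold higher number from compound 3 to compound 4 (0.14 log units; that floor lies within the scatter). The steps to compound 4 from compound 1 and compound 2 cannot be read, because both ends of each are limits: the limit of > 125000 nM in this assay, at which 3 of the 4 values shown sit.

From the compounds shown here alone, the true values of compound 1, compound 2 and compound 4 remain open. So does the reading with an amine or a carboxylic acid on the phenyl ring in place of fluorine.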